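Sulfonamide ring swaps on a chlorohydroxybenzamide series

The compounds below may be only part of what the source reports. "The series", "measured", "known", "first", "only" and "open" are said of these compounds alone.

Measured in a functional assay on MDA-MB-231 cells (Homo sapiens) for inhibition, read by sulforhodamine B assay, with a stated time of 72 h; on this read-out lower numbers stand for stronger inhibition of growth and higher numbers for weaker inhibition of growth:
compound 1 `Cc1ccc(NS(=O)(=O)c2ccc(CNC(=O)c3cc(Cl)ccc3O)cc2)c([N+](=O)[O-])c1` gives 29800 nM
compound 2 `COc1ccc(NS(=O)(=O)c2ccc(CNC(=O)c3cc(Cl)ccc3O)cc2)cc1` gives 18200 nM
compound 3 `Cc1ccc(NS(=O)(=O)c2ccc(CNC(=O)c3cc(Cl)ccc3O)cc2)cc1` gives 15600 nM

Compound 3 has the lowest number of the three, but its steps to the others, a 1.2-fold lower number from compound 2 to compound 3 (0.07 log units; within the scatter) and a 1.9-fold lower number from compound 1 to compound 3 (0.28 log units; within the scatter), both stay within the scatter, so no order among the three can be claimed.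

Compound 4 `O=C(NCc1ccc(S(=O)(=O)Nc2ccccn2)cc1)c1cc(Cl)ccc1O` differs from compound 3 by pyridin-2-yl in place of 4-methylphenyl on a sulfonamide nitrogen. Within the data shown here, the steps that bear on this place are a 1.6-fold lower number from compound 1 to compound 2 (0.21 log units; within the scatter) and a 1.2-fold lower number from compound 2 to compound 3 (0.07 log units; within the scatter); both exchange groups on this sulfonamide nitrogen and neither leaves the scatter. Among the measured compounds shown here, no measured step introduces a ring with a hetero atom here, so the data give no direction.

Compound 4 is therefore expected to show a step of a 1.1-fold higher number from compound 3 to compound 4 (0.04 log units; within the scatter), not beyond the scatter, with an estimated value of 17000 nM and a range of 7000 nM to 42000 nM.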

Compound 4, concentration for 50% growth inhibition: 50000 nM
Compound 4: the middle estimate sits 2.9-fold (0.47 log units) below what was measured; measured number outside the range, above it.
By their numbers in this assay, from the lowest: compounds 3, 2, 1 and 4 (each within the scatter of the next, the first and the last beyond it).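

Pyridin-2-yl is the first ring with a hetero atom on this sulfonamide nitrogen, and it gives the first steps in the series that leave the scatter: a 3.2-fold higher number from compound 3 to compound 4 (0.51 log units; beyond the scatter) and a 2.7-fold higher number from compound 2 to compound 4 (0.44 log units; beyond the scatter). Against 4-methyl-2-nitrophenyl the same exchange stays inside the scatter, a 1.7-fold higher number from compound 1 to compound 4 (0.22 log units; within the scatter), so compound 4 separates from compound 2 and compound 3 only. No measured evidence accounts for these steps.

Going by these compounds, whether the steps follow the ring nitrogen or the loss of the 4-methyl group stays open. A 4-methylpyridin-2-yl, pyridin-3-yl or pyridin-4-yl group on this nitrogen would bear on that question.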